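Chloro for fluoro on two quinone cores

The source may hold more compounds than are shown below. What is called first, only, known or untested is meant among the compounds shown, and "the series" means these compounds.

Measured compounds:
compound 1 `O=C1C(Nc2ccc(F)cc2)=CC(=O)c2ncccc21`, 79%
compound 2 `O=C1C(Nc2ccc(Cl)cc2)=CC(=O)c2ncccc21`, 86%
compound 3 `O=C1C=C(Nc2ccc(F)cc2)C(=O)c2cnccc21`, 72%

Of the compounds shown here, three have been measured in a functional assay on the whole organism (aorta) with Rattus norvegicus as the target; a higher number here means a larger maximal response, a lower number a smaller maximal response. Compound 1 and compound 2 share one core, and the step between them is a number 7 percentage points higher from compound 1 to compound 2 (within the scatter); the change is chloro in place of fluoro on an aromatic carbon. Compound 3 has the same atoms as compound 1, joined differently; the difference between the two cores is not broken down here. In this assay compound 3 stands lowest of the three numbers, within the scatter of compound 1 and beyond the scatter of compound 2.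

Compound 4 `O=C1C=C(Nc2ccc(Cl)cc2)C(=O)c2cnccc21` has not yet been measured. It differs from compound 3 by chloro in place of fluoro on an aromatic carbon, the same change as that from compound 1 to compound 2, made on the core of compound 3 instead. The change occurs twice among these compounds, once measured. Within the data shown here, since the two "place" descriptions agree word for word, the change is taken as the same, and the only available step is the small one from compound 1 to compound 2.

The step from compound 3 to compound 4 in this assay is expected to be a number 7 percentage points higher from compound 3 to compound 4 (within the scatter), of about the size seen because of a number 7 percentage points higher from compound 1 to compound 2 (within the scatter). Compound 4 is therefore estimated at 79%, most likely between 67% and 91%.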

Compound 4, largest response reached (Emax), in percent of the reference or control that the assay uses: 96%
The estimate for compound 4 lay 17 percentage points below the measured number; the whole stated range lies below it.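

Chloro in place of fluoro on an aromatic carbon does not carry over from one core to the other at a fixed size in this assay; the two steps differ: the same change on two cores in this assay, a number 7 percentage points higher (within the scatter) from compound 1 to compound 2 and a number 24 percentage points higher (beyond the scatter) from compound 3 to compound 4, 17 percentage points apart, beyond the scatter of two such steps

On the core of compound 3 the new step is a number 24 percentage points higher from compound 3 to compound 4 (beyond the scatter), so a step read on the core of compound 1 gave no reliable size for this core, and on that first core no direction can be claimed for the change at all. Among these compounds, what this does not show is which feature of the two cores goes with the larger step, or whether either size would hold on a further core, since the comparison rests on only two pairs, one exchange of halogens and a single read-out.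

Open, from the compounds shown here alone, is how other groups on the same aromatic carbon, such as bromo, methoxy, an amine or a carboxylic acid, would behave on these two cores, and whether they too would give steps of different size. Also open, going by these compounds, is whether replacing the chloro or fluoro with a hydrogen would separate the two cores in this assay in the same way.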